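A few compounds are considered here, and "the series" means these few. Any claim that something is new, unique, unknown or untested is made for them only; others in the source may bear on it.

Working notes on the series. Compound 1 `COc1ccc(C(=O)NC(=S)N2CCc3c(OCCCCCOc4ccc(Cl)cc4)cccc32)cc1` and compound 2 `O=C(NC(=S)N1CCc2c(OCCCCCOc3ccc(Cl)cc3)cccc21)C1CCCC1` share one core and differ only in the group on the carbonyl carbon, cyclopentyl in place of 4-methoxyphenyl. In an ADME assay on Huh-7 cells (Homo sapiens) for cytotoxicity (a higher number here means that more compound is tolerated, a lower number that less compound is tolerated), compound 1 gives 34400 nM. In this assay compound 2 gives only a limit, > 50000 nM, not a number (the limit of > 50000 nM in this assay, at which 1 of the 2 values shown sits). Compound 2 therefore stands at the upper edge of what this assay can show, and the step of an at least 1.4-fold higher number from compound 1 to compound 2 (0.16 log units; that floor lies within the scatter) is a floor that lies within the scatter.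

Compound 3 `O=S(=O)(NC(=S)N1CCc2c(OCCCCCOc3ccc(Cl)cc3)cccc21)c1ccccc1` is not yet measured. Its change from compound 2 (phenylsulfonyl in place of cyclopentylcarbonyl on an amide-type nitrogen). Within the data shown here, only the step from compound 1 to compound 2 touches the same position, and that step gave no more than a floor within the scatter. Among the measured compounds shown here, no measured compound carries a sulfonyl group, so the series gives no direction for this change. In this assay no step beyond the scatter is expected, and a further limit is the likelier outcome. Compound 3 is estimated at 45000 nM, with a range from 20000 nM to 100000 nM. The expected step of an at least 1.1-fold lower number from compound 2 to compound 3 (0.04 log units; that floor lies within the scatter) stays within the scatter.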

Compound 3, half-maximal cytotoxic concentration: > 50000 nM
Compound 3: only a limit was reported (the forecaster's own chance of this, stated with the estimate: 55%); at least 1.1-fold (0.04 log units) between middle value and limit.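

In this assay compound 3 gives only a limit, > 50000 nM, not a number. Phenylsulfonyl on the amide-type nitrogen, the first sulfonyl group in the series, gives an at least 1.4-fold higher number from compound 1 to compound 3 (0.16 log units; that floor lies within the scatter), so this change, like the change to cyclopentylcarbonyl, gives no reading of less compound being tolerated than for compound 1. The step between compound 2 and compound 3 cannot be read, and the order of cyclopentylcarbonyl and phenylsulfonyl at this position stays undecided, since both compounds sit at the same edge of the range: the limit of > 50000 nM in this assay, at which 2 of the 3 values shown sit.

As far as these compounds go, how far compound 2 and compound 3 lie past that limit stays open, so the three compounds show no trend at this position beyond the value of compound 1. Also open, from the compounds shown here alone, is whether a group of another kind on this nitrogen, such as methylsulfonyl, an aminoacetyl group or a carboxylic acid on the phenyl ring of phenylsulfonyl, would bring a number inside the range of this assay.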